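The compounds below may be only part of what the source reports. "The series", "measured", "known", "first", "only" and "open" are said of these compounds alone.

Measured compounds:
- Compound 1 `COc1cc(/C=C/C(=O)O)ccc1OC(=O)c1nc(C)c(C)nc1C`: 55.4%
- Compound 2 `COc1ccc(/C=C/C(=O)O)cc1OC(=O)c1nc(C)c(C)nc1C`: 216%
- Compound 3 `Cc1nc(C)c(C(=O)Oc2ccc(/C=C/C(=O)O)cc2)nc1C`: 93.2%

All three were tested in a functional assay on EA.hy 926 cells (Homo sapiens) for cytotoxicity, read by MTT assay, with stated times of 24 h and 12 h, tested at 100 uM; a lower number here means a weaker effect, a higher number a stronger effect of the compound at the concentration tested. Compound 2 gives the highest number of the three. How the core of compound 2 differs from that of compound 1 is not broken down here. Compound 4 `Cc1nc(C)c(C(=O)Oc2cccc(/C=C/C(=O)O)c2)nc1C` is not yet measured; it differs from compound 2 by hydrogen in place of methoxy on an aromatic carbon. The same kind of change was made from compound 1 to compound 3, (hydrogen in place of methoxy on an aromatic carbon), where the place is meta to a 2-carboxyethenyl group rather than para to it, and there it gave a number 37.8 percentage points higher from compound 1 to compound 3 (beyond the scatter). Because a number 37.8 percentage points higher from compound 1 to compound 3 (beyond the scatter) was a rise, a rise is also expected from compound 2 to compound 4, though with wide uncertainty, since the place is not the same and compound 2 already starts high; the expected step is a number 19 percentage points higher from compound 2 to compound 4 (beyond the scatter). Compound 4 is therefore estimated to give 235%, most likely between 140% and 320%.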

Compound 4, a percentage reported as activity, at one concentration (the size of the read-out at that concentration, not a potency): 103%
For compound 4 the middle estimate is 132 percentage points above the measured one, outside the stated range (below it).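

In this assay, putting hydrogen in place of methoxy gives a number 113 percentage points lower from compound 2 to compound 4 (beyond the scatter), so the step seen on one core does not carry over to the other, even in direction: the same change on two cores in this assay, a number 37.8 percentage points higher (beyond the scatter) from compound 1 to compound 3 and a number 113 percentage points lower (beyond the scatter) from compound 2 to compound 4, 150.8 percentage points apart, beyond the scatter of two such steps. For these two pairs, then, the result of this change on one core is a poor guide to its result on another. The two pairs show that the outcome differs, but not why it differs, nor which way the change would go on a further core.

From the compounds shown here alone, it remains open whether a hydroxyl group or a fluorine atom in that place would show the same split between the two cores. Going by these compounds, it also remains open whether an amide in place of the ester link would alter the picture.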